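Ethoxycarbonyl to carboxy on the shared core

The source may report more compounds than this note shows. Statements on the series, on what has been measured and on what is new or still open speak of the compounds shown alone.

In a functional assay on A549 cells (Homo sapiens) for cytotoxicity, read by MTT assay, with a stated time of 72 h (on this read-out lower numbers stand for stronger inhibition and higher numbers for weaker inhibition), compound 2 `CCOC(=O)c1c(C)oc2ncnc(Nc3ccccc3)c12` gives > 1000000 nM, which is a limit and not a number. Compound 3 `CCOC(=O)c1c(C)oc2ncnc(Nc3ccc(OCc4ccc(C)cc4)cc3)c12` gives > 1000000 nM, also a limit. Between them lies a step that the two limits leave unreadable from compound 2 to compound 3, with (4-methylbenzyl)oxy in place of hydrogen on an aromatic carbon. That shared limit is the limit of > 1000000 nM in this assay, at which 2 of the 3 values shown sit. Compound 4 `Cc1oc2ncnc(Nc3ccccc3)c2c1C(=O)O` has hydrogen in place of ethyl on an oxygen next to a carbonyl group. Among the measured compounds shown here, no measured step covers this change. For the measured compounds named here, the only guide is compound 1 `Cc1oc2ncnc(Nc3cccc(Br)c3)c2c1C(=O)O`, a carboxy compound that gives a number in this assay, 43000 nM. The expected move is an at least 8.3-fold lower number from compound 2 to compound 4 (0.92 log units; beyond the scatter), toward stronger inhibition. Compound 4 is estimated at 120000 nM, with an expected range of 30000 nM to 600000 nM.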

Compound 4, half-maximal inhibitory concentration: 191000 nM
Estimate against measurement, compound 4: 1.6-fold (0.20 log units) below; the measured number falls inside the stated range.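

In this assay, ethoxycarbonyl to carboxy on the shared core gives an at least 5.2-fold lower number from compound 2 to compound 4 (0.71 log units; beyond the scatter). This size is only a minimum, since compound 2 stands at a limit and not a number: the limit of > 1000000 nM in this assay, at which 2 of the 4 values shown sit.

With the carboxy group kept, hydrogen in place of bromo on an aromatic carbon gives a 4.4-fold higher number from compound 1 to compound 4 (0.65 log units; beyond the scatter), so the carboxy compounds also respond to a change at the other end of the molecule.

As far as these compounds go, whether carboxy has a similar effect alongside the (4-methylbenzyl)oxy group of compound 3 stays open. From the compounds shown here alone, the outcome with an amide or a hydroxymethyl group in place of carboxy is also open.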